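Methylating the sulfonamide nitrogen of compound 3

The compounds below may be only part of what the source reports. "The series", "measured", "known", "first", "only" and "open" are said of these compounds alone.

Compound 1 `O=C(NC[C@@H]1CCCc2cc(S(=O)(=O)c3cccc(F)c3)ccc21)[C@H]1CCCN1` — 0.631 nM
Compound 2 `O=C1CN(C[C@@H]2CCCc3cc(S(=O)(=O)c4cccc(F)c4)ccc32)CCN1` — 6.31 nM
Compound 3 `CS(=O)(=O)NC[C@@H]1CCCc2cc(S(=O)(=O)c3cccc(F)c3)ccc21` — 0.2 nM

Three compounds share a core and differ in the group on the saturated chain carbon. In an assay on isolated protein for displacement of a labelled ligand from 5-hydroxytryptamine receptor 6 (Homo sapiens) (on this read-out higher numbers stand for weaker inhibition and lower numbers for stronger inhibition), compound 3 gives the lowest number of the three: it stands a 3.2-fold lower number from compound 1 to compound 3 (0.50 log units; beyond the scatter) and a 32-fold lower number from compound 2 to compound 3 (1.50 log units; beyond the scatter). Compound 4 `CN(C[C@@H]1CCCc2cc(S(=O)(=O)c3cccc(F)c3)ccc21)S(C)(=O)=O` keeps the methanesulfonamido group of compound 3 and changes it in one place: methyl in place of hydrogen on a sulfonamide nitrogen.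

Among the compounds with values here, none of the measured steps concerns this nitrogen directly. The two steps ending at compound 3 swap the whole group and were modest and large, which shows that the numbers at this position move over a wide span; they say nothing about a methyl on the sulfonamide nitrogen. Within the data shown here, with no direct precedent, compound 4 is expected to stay close to compound 3, with a slight move toward a higher number as the more likely direction, a 2.0-fold higher number from compound 3 to compound 4 (0.30 log units; within the scatter). Compound 4 is therefore estimated at 0.4 nM, within 0.12 nM to 1.3 nM.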

Compound 4, inhibition constant: 0.398 nM
Compound 4: the middle estimate sits 1.0-fold (0.00 log units) above what was measured, within the range that was stated.
By their numbers in this assay, from the lowest: compounds 3, 4 and 1 (each within the scatter of the next, the first and the last beyond it); then compound 2.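

On the sulfonamide nitrogen, in this assay, methyl in place of hydrogen leaves the two compounds indistinguishable (a 2.0-fold higher number from compound 3 to compound 4 (0.30 log units; within the scatter)), so a hydrogen on this nitrogen is not required for a value in this range. The methylated group keeps the clear separation from the 3-oxopiperazin-1-yl group (a 16-fold lower number from compound 2 to compound 4 (1.20 log units; beyond the scatter)), whereas its gap to the ((pyrrolidin-2-yl)carbonyl)amino group lies within the scatter (a 1.6-fold lower number from compound 1 to compound 4 (0.20 log units; within the scatter)), unlike the gap measured for the unmethylated group (a 3.2-fold lower number from compound 1 to compound 3 (0.50 log units; beyond the scatter)). No measurement offered here accounts for this result.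

The compounds shown leave open whether an ethyl group or a longer chain on the sulfonamide nitrogen would stay in this range. On these data alone, it is also open how an amine or a carboxylic acid carried on that nitrogen would read.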